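Replacing an aminopropyl amide with a methylpiperidine amide

The compounds below may be only part of what the source reports. "The series", "measured", "known", "first", "only" and "open" are said of these compounds alone.

Compound 3 `CC(C)(C)c1ccc(C(=O)N2CCC3(CC2)C(=O)N(CC(=O)NCCCN)CN3c2ccccc2)cc1` gives the lowest number of the three compounds measured in an assay on HEK293 cells for displacement of a labelled ligand from NPC1-like intracellular cholesterol transporter 1 (Homo sapiens) (on this read-out higher numbers stand for weaker inhibition and lower numbers for stronger inhibition), at 4200 nM. Compound 1 `CC(C)(C)OC(=O)NCCNC(=O)CN1CN(c2ccccc2)C2(CCN(C(=O)c3ccc(C(C)(C)C)cc3)CC2)C1=O` gives 10900 nM in this assay, and compound 2 `CC(C)(C)c1ccc(C(=O)N2CCC3(CC2)C(=O)N(CC(=O)N2CCN(S(C)(=O)=O)CC2)CN3c2ccccc2)cc1` gives 19000 nM. Compound 4 `CC1CCCN(C(=O)CN2CN(c3ccccc3)C3(CCN(C(=O)c4ccc(C(C)(C)C)cc4)CC3)C2=O)C1` is not yet measured; it differs from compound 3 by 3-methylpiperidin-1-yl in place of (3-aminopropyl)amino on a carbonyl carbon. Among the compounds with values here, two measured steps bear on this. The step of a 4.5-fold lower number from compound 2 to compound 3 (0.66 log units; beyond the scatter) put the (3-aminopropyl)amino group in place of a ring carrying no hydrogen-bond donors, and the step of a 2.6-fold lower number from compound 1 to compound 3 (0.41 log units; beyond the scatter) also lowered the number when aminomethyl replaced (tert-butoxycarbonyl)amino. Compound 4 takes that amine away again and carries a ring with no donors, so a higher number is expected, a step of about a 3.6-fold higher number from compound 3 to compound 4 (0.55 log units; beyond the scatter). Compound 4 is therefore estimated at 15000 nM, within a range from 6000 nM to 40000 nM.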

Compound 4, half-maximal inhibitory concentration: 12000 nM
Compound 4: the middle estimate sits 1.3-fold (0.10 log units) above what was measured, within the range that was stated.
By their numbers in this assay, from the lowest: compound 3; then compounds 1, 4 and 2 (each within the scatter of the next).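

In this assay, the change on this carbonyl carbon gives a 2.9-fold higher number from compound 3 to compound 4 (0.46 log units; beyond the scatter), so a second ring with no hydrogen-bond donors also fails to match the (3-aminopropyl)amino chain. The two rings cannot be told apart, with a 1.6-fold lower number from compound 2 to compound 4 (0.20 log units; within the scatter), and the Boc-capped chain cannot be told from the new ring either, with a 1.1-fold higher number from compound 1 to compound 4 (0.04 log units; within the scatter). Nothing available explains why the chain with the free amine stands apart.

Going by these compounds, it remains open whether the free amine or the open chain matters more. A 3-(aminomethyl)piperidin-1-yl ring or a shorter (2-aminoethyl)amino chain would help separate the two.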